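Chloro for methoxy on the second aryl of compound 2

The source may hold more compounds than are shown below. What is called first, only, known or untested is meant among the compounds shown, and "the series" means these compounds.

Compound 2 `COc1ccc(C2=NN(C3=NC(=O)/C(=C4\C(=O)Nc5ccccc54)S3)C(c3ccc(OC)cc3)C2)cc1` gives the highest of the three numbers in a functional assay on cells (Melanoma cell, Homo sapiens) for cytotoxicity, read by sulforhodamine B assay, with a stated time of 48 h (a higher number here means a weaker inhibitor of growth, a lower number a stronger inhibitor of growth), at 100000 nM. Compound 1 `COc1ccc(C2CC(c3ccccc3)=NN2C2=NC(=O)/C(=C3\C(=O)Nc4ccccc43)S2)cc1` gives 2000 nM in this assay, and compound 3 `COc1ccc(C2=NN(C3=NC(=O)/C(=C4\C(=O)Nc5ccc(Br)cc54)S3)C(c3ccc(OC)cc3)C2)cc1` gives 190 nM. Compound 4 `COc1ccc(C2=NN(C3=NC(=O)/C(=C4\C(=O)Nc5ccccc54)S3)C(c3ccc(Cl)cc3)C2)cc1` differs from compound 2 by chloro in place of methoxy on an aromatic carbon. The step that bears most directly on this change is a 50-fold higher number from compound 1 to compound 2 (1.70 log units; beyond the scatter), which concerns the same six-membered ring; a 530-fold lower number from compound 2 to compound 3 (2.72 log units; beyond the scatter) sits on a different ring and only shows how far the numbers can move in this series. Since removing the methoxy gave a 50-fold higher number from compound 1 to compound 2 (1.70 log units; beyond the scatter), a chloro in its place is expected to lower the number substantially in this assay, by about a 67-fold lower number from compound 2 to compound 4 (1.82 log units; beyond the scatter), with the exact size uncertain. Compound 4 is therefore estimated at 1500 nM, within 200 nM to 12000 nM.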

Compound 4, concentration for 50% growth inhibition: 100000 nM
Beside the measured number, compound 4's estimate is 67-fold (1.82 log units) below it, outside the stated range (above it).
By their numbers in this assay, from the lowest: compound 3; then compound 1; then compounds 2 and 4 (each within the scatter of the next).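

In this assay, 4-methoxyphenyl to 4-chlorophenyl gives no change at the digits printed from compound 2 to compound 4 (within the scatter), so the two groups are not separated at this position on the core without bromo. The methoxy added in a 50-fold higher number from compound 1 to compound 2 (1.70 log units; beyond the scatter) sits on the other aryl ring and stays in compound 4, so that large step does not describe this position. No measurement at hand accounts for this result. Still open, going by these compounds, is whether an amine or a carboxylic acid here would move the number, and whether chloro and methoxy remain inseparable with the bromo of compound 3 on the core.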